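The source may hold more compounds than are shown below. What is called first, only, known or untested is meant among the compounds shown, and "the series" means these compounds.

Compound 1 `Cn1c(-c2ccccc2C(F)(F)F)nnc1C12CCC(CCS(=O)(=O)C(C)(C)C)(CC1)CC2`: 65%
Compound 2 `CCS(=O)(=O)CCC12CCC(c3nnc(-c4ccccc4C)n3C)(CC1)CC2`: 86%
Compound 3 `CCS(=O)(=O)CCC12CCC(c3nnc(-c4ccccc4Br)n3C)(CC1)CC2`: 86%

In a functional assay on the whole organism (strain ICR) for inhibition, with Mus musculus as the target, with a stated time of 4 h, at a dose of 10 mg/kg by the oral route (on this read-out higher numbers stand for more inhibition at the one dose given (going by the name of the read-out) and lower numbers for less inhibition), compound 1 stands lowest of the three numbers; compound 2 and compound 3 both lie higher, beyond the scatter. The step that leads to compound 4 `Cn1c(-c2ccccc2C(F)(F)F)nnc1C12CCC(COc3ccc(S(C)(=O)=O)cc3)(CC1)CC2` alters the side chain of compound 1: 4-(methylsulfonyl)phenoxy in place of ((tert-butyl)sulfonyl)methyl on a saturated chain carbon bound to a saturated ring carbon. Among the measured compounds shown here, the only measured step, no change at the digits printed from compound 2 to compound 3 (within the scatter), concerns a substituent on the aromatic ring and leaves the side chain untouched, so it does not bear on this change. For the measured compounds named here, no measured step therefore tells how the side chain affects this assay, and the direction of the step is open. The step from compound 1 to compound 4 is expected to be small, no change at the digits printed from compound 1 to compound 4 (within the scatter), within the scatter. Compound 4 is estimated at 65%, in the range 35% to 90%.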

Compound 4, a percentage reported as inhibition, in the whole organism at one dose (the size of the read-out at that dose, not a potency): 79%
For compound 4 the middle estimate is 14 percentage points below the measured one, and the stated range covers the measured number.
By their numbers in this assay, from the lowest: compound 1; then compounds 4, 2 and 3 (each within the scatter of the next).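

In this assay, the side chain on the saturated chain carbon bound to a saturated ring carbon proves able to shift the read-out: 4-(methylsulfonyl)phenoxy in place of ((tert-butyl)sulfonyl)methyl gives a number 14 percentage points higher from compound 1 to compound 4 (beyond the scatter). This place on the shared core therefore accepts a group holding a six-membered aromatic ring without loss of inhibition at this dose. No measurement on hand explains this step.

The aromatic ring, the ether oxygen and the methylsulfonyl group all enter together, so the compounds shown do not separate their shares. Plain phenoxy or an amine in the same place would be informative comparisons.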